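From diethylamino to (piperazin-1-yl)methyl on the side chain

The source may hold more compounds than are shown below. What is called first, only, known or untested is meant among the compounds shown, and "the series" means these compounds.

Measured compounds:
compound 1 `CCN(CC)CCCOc1cc(O)c2c(=O)cc(-c3ccccc3)oc2c1OC` — 1830 nM
compound 2 `COc1c(O)cc(O)c2c(=O)cc(-c3cccc(F)c3)oc12` — "not determined" (no result reported)
compound 3 `CN(C)CCCOc1c(O)cc(O)c2c(=O)cc(-c3ccccc3)oc12` — > 100000 nM

Three compounds share the core of compound 1, but only one of them comes with a full number. Among the measured compounds shown here, in a functional assay on A549 cells (Homo sapiens) for cytotoxicity, read by MTT assay, with a stated time of 48 h (on this read-out lower numbers stand for stronger inhibition and higher numbers for weaker inhibition), compound 1 gives 1830 nM, and this is the single measured value in the set. For compound 3 the read-out is a limit of the assay rather than a number, > 100000 nM. That one entry is described by the limit of > 100000 nM in this assay, at which 1 of the 3 values shown sits. For compound 2 no result is reported in this assay, "not determined" (no result reported). For the measured compounds named here, because no pair of measured compounds differs in a single place, nothing in these data shows how any one change shifts the read-out.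

Compound 4 `COc1c(OCCCCN2CCNCC2)cc(O)c2c(=O)cc(-c3ccccc3)oc12` has not been measured. It differs from compound 1 by (piperazin-1-yl)methyl in place of diethylamino on a saturated chain carbon, three bonds along the chain from an oxygen on an aromatic ring. The ether oxygen and the saturated chain between it and the amine are kept; only the amine at the end of the chain is exchanged.

Going by the values given here, with no measured step of this kind to lean on, the expectation rests on compound 1 alone. The expected step is a 1.6-fold higher number from compound 1 to compound 4 (0.21 log units; within the scatter), a small loss in this assay. Compound 4 is therefore estimated at 3000 nM in this assay, with a range from 800 nM to 12000 nM.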

Compound 4, half-maximal inhibitory concentration: 1740 nM
Compound 4: the middle estimate sits 1.7-fold (0.24 log units) above what was measured, within the range that was stated.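

The exchange gives the first readable step among these compounds: in this assay the change reads a 1.1-fold lower number from compound 1 to compound 4 (0.02 log units; within the scatter), so compound 1 and compound 4 cannot be told apart. On a saturated chain carbon, three bonds along the chain from an oxygen on an aromatic ring, the open diethylamino end can thus give way to (piperazin-1-yl)methyl, which brings in a six-membered non-aromatic ring and a hydrogen-bond donor, and the number stays within the scatter; cut one bond further out, the same difference reads 3-(diethylamino)propyl to 4-(piperazin-1-yl)butyl. No measurement shown offers a reason for this outcome.

This single step does not show whether the chain end or the chain length matters more, since the amine and the chain name change together, and it leaves open how a morpholine, a piperidine or a carboxylic acid at the end of the chain would read. Going by these compounds, it is also open how a shorter chain or a longer chain carrying the same piperazine would compare in this assay.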